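Straight Chain in Place of a Branched One

The source may report more compounds than this note shows. Statements on the series, on what has been measured and on what is new or still open speak of the compounds shown alone.

Measured in a functional assay on HUVEC cells (Homo sapiens) for inhibition, tested at 5 ug/mL; on this read-out higher numbers stand for a stronger effect at the one concentration tested and lower numbers for a weaker effect:
compound 1 `COc1cc(/C=C/C(=O)c2cccc(NC(=O)c3ccco3)c2)ccc1O` gives 82%
compound 2 `COc1cc(/C=C/C(=O)c2cccc(NC(=O)C(C)C)c2)ccc1O` gives 51%

Compound 2 stands lowest of these two numbers. Going by the values given here, the only measured step, a number 31 percentage points lower from compound 1 to compound 2 (beyond the scatter), is large and beyond the scatter. Compound 3 `CCCC(=O)Nc1cccc(C(=O)/C=C/c2ccc(O)c(OC)c2)c1` differs from compound 2 by propyl in place of isopropyl on a carbonyl carbon. Among the compounds with values here, no measured step bears on this change: the one known step swaps a ring for a chain, not one chain for another. Therefore no step beyond the scatter in this assay is expected. Compound 3 is estimated at 52%, between 35% and 70%. The expected step is a number 1 percentage points higher from compound 2 to compound 3 (within the scatter).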

Compound 3, a percentage reported as inhibition, at one concentration (the size of the read-out at that concentration, not a potency): 57%
The estimate for compound 3 lay 5 percentage points below the measured number, and the stated range covers the measured number.
By their numbers in this assay, from the lowest: compounds 2 and 3 (each within the scatter of the next); then compound 1.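

In this assay, propyl in place of isopropyl on the carbonyl carbon gives a number 6 percentage points higher from compound 2 to compound 3 (within the scatter), so the straight and the branched chain cannot be told apart here. Propyl in place of furan-2-yl gives a number 25 percentage points lower from compound 1 to compound 3 (beyond the scatter), so the lower reading is not confined to the branched chain: both chains stand clearly below the furan-2-yl compound. Nothing available explains this difference between the ring and the chains. Still open, from the compounds shown here alone, is whether a longer chain such as pentyl, or another ring such as phenyl or thiophene, would match compound 1.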